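A few compounds are considered here, and "the series" means these few. Any claim that something is new, unique, unknown or untested is made for them only; others in the source may bear on it.

Values in a functional assay on A2780 cells (Homo sapiens) for cytotoxicity, read by MTT assay, with a stated time of 72 h; on this read-out higher numbers stand for weaker inhibition and lower numbers for stronger inhibition:
- compound 1 `O=C(CCCCCN(CC(=O)NC1CCCCC1)C(=O)c1cccc2ccccc12)NO`: 260 nM
- compound 2 `CN(C)c1ccc(C(=O)N(CCCCCC(=O)NO)CC(=O)NC2CCCCC2)cc1`: 1540 nM
- compound 3 `Cc1cc(C)cc(C(=O)N(CCCCCC(=O)NO)CC(=O)NC2CCCCC2)c1`: 160 nM

Compound 3, at 160 nM, cannot be separated from compound 1, as a 1.6-fold lower number from compound 1 to compound 3 (0.21 log units; within the scatter) shows. It stands clearly apart from compound 2, as a 9.6-fold lower number from compound 2 to compound 3 (0.98 log units; beyond the scatter) shows.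

Compound 4 `Cc1ccc(NC(=O)CN(CCCCCC(=O)NO)C(=O)c2cc(C)cc(C)c2)cc1` keeps the 3,5-dimethylphenyl group of compound 3 on the carbonyl carbon and differs elsewhere: 4-methylphenyl in place of cyclohexyl on an amide-type nitrogen. In words, 4-methylphenyl comes in place of cyclohexyl on an amide-type nitrogen.

Within the data shown here, no measured step touches this place. All three compounds carry cyclohexyl, and every measured step changes the group on the carbonyl carbon. The steps of a 5.9-fold higher number from compound 1 to compound 2 (0.77 log units; beyond the scatter) and a 9.6-fold lower number from compound 2 to compound 3 (0.98 log units; beyond the scatter) show that this other place can move the number, but they give neither a size nor a direction for the change at hand. The step of a 1.6-fold lower number from compound 1 to compound 3 (0.21 log units; within the scatter) shows that one exchange of groups there stayed within the scatter. With no direct evidence, the working expectation is no step beyond the scatter, with a slight lean towards a higher number held only loosely.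

The step expected in this assay is a 1.4-fold higher number from compound 3 to compound 4 (0.14 log units; within the scatter). For compound 4 the estimated value is 220 nM, with an expected range of 70 nM to 700 nM.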

Compound 4, half-maximal inhibitory concentration: 1270 nM
Compound 4: the middle estimate sits 5.8-fold (0.76 log units) below what was measured, and the stated range ends below it.
By their numbers in this assay, from the lowest: compounds 3 and 1 (each within the scatter of the next); then compounds 4 and 2 (each within the scatter of the next).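

Working notes on the group on the amide-type nitrogen: in this assay, with the 3,5-dimethylphenyl group held on the carbonyl carbon, exchanging cyclohexyl for 4-methylphenyl gives a 7.9-fold higher number from compound 3 to compound 4 (0.90 log units; beyond the scatter). Among these compounds, the earlier compounds all carried cyclohexyl and varied only on the carbonyl carbon, so this is the first sign that this place can also move the number, and here the move is upward and beyond the scatter, from one six-membered carbon ring to another that is aromatic and carries a methyl group. Nothing measured in the series accounts for the rise, so it stands as an observation only.

Still open, from the compounds shown here alone, is which part of the exchange carries the step: unsubstituted phenyl, or a 4-methylcyclohexyl group, would separate the aromatic ring from the added methyl. Also open, going by these compounds, is whether the same exchange gives a step of similar size with the naphthalen-1-yl group of compound 1 on the carbonyl carbon, and whether a benzyl group or a smaller ring such as cyclopentyl on this nitrogen stays within the scatter of compound 3.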